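This account rests on a few compounds, and the source may have more. Where it says the series, first, only, none or still open, it means among the compounds named here.

Measured so far in an ADME assay on RAW264.7 cells (Mus musculus) for cytotoxicity, read by MTT assay, with a stated time of 24 h, tested at 1.25 ug/mL; a higher number here means a weaker effect of the compound at the concentration tested, a lower number a stronger effect:

compound 1, `COc1ccc(C(=O)/C=C/c2cccc(OC)c2OC)c(O)c1`: 94.2%
compound 2, `COc1cc(C(=O)CCc2cccc(OC)c2OC)ccc1O`: 94.1%
compound 3, `COc1ccc(C(=O)/C=C/c2cc(OC)ccc2OC)c(O)c1`: 95.4%

Compound 1 stands second highest of the three numbers. Its nearest neighbour is compound 2, lower by an amount within the scatter; compound 3 is the furthest, higher, yet also within the scatter. The three values therefore cannot be ordered; all three show a weak effect at the concentration tested.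

Compound 4, `COc1ccc(C(=O)/C=C/c2ccc(OC)c(OC)c2OC)c(O)c1`, differs from compound 1 by methoxy in place of hydrogen on an aromatic carbon. Among the measured compounds shown here, no step between two measured compounds that differ in one place is available, so the change has no precedent in this set. Because compound 1 gives 94.2% and compounds 2 and 3 sit with it inside the scatter, the step of a number 0.2 percentage points lower from compound 1 to compound 4 (within the scatter) is expected to be none beyond the scatter. Compound 4 is estimated at 94%, in the range 85% to 100%.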

Compound 4, a percentage reported as activity, at one concentration (the size of the read-out at that concentration, not a potency): 98.5%
Estimate against measurement, compound 4: 4.5 percentage points below; the measured number falls inside the stated range.
By their numbers in this assay, from the lowest: compounds 2, 1, 3 and 4 (each within the scatter of the next).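

In this assay, methoxy in place of hydrogen on an aromatic carbon, ortho to a methoxy group and para to a large group, gives a number 4.3 percentage points higher from compound 1 to compound 4 (within the scatter) and so leaves the read-out unchanged within the scatter. Among the compounds shown here, this position therefore tolerates the added methoxy at the concentration tested, in the first single-place step. Nothing measured here bears on the reason for this result.

On these data alone, whether a carboxylic acid or an amine at this position would shift the read-out beyond the scatter remains open. Also open, as far as these compounds go, is whether the same methoxy change on compound 2 would behave alike.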